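The source may report more compounds than this note shows. Statements on the series, on what has been measured and on what is new or still open speak of the compounds shown alone.

Compound 1 `CCOC(=O)[C@@H]1CCCN(S(=O)(=O)c2ccc(S(=O)(=O)N3CCOCC3)cc2)C1` — 23400 nM
Compound 2 `CCOC(=O)[C@@H]1CCCN(S(=O)(=O)c2ccc(S(=O)(=O)N(CC)CC)cn2)C1` — 1400 nM

In a functional assay on BXPC-3 cells (Homo sapiens) for inhibition, read by MTT assay, with a stated time of 7 days (a lower number here means a stronger inhibitor, a higher number a weaker inhibitor), compound 1 gives 23400 nM and compound 2 gives 1400 nM; compound 1 therefore has the higher of the two numbers, and the two values lie beyond the usual scatter of each other. Compound 3 `CCCN(CC)S(=O)(=O)c1ccc(S(=O)(=O)N2CCC[C@@H](C(=O)OCC)C2)cc1` is made from compound 1 by one change: ethyl(propyl)amino in place of morpholin-4-yl on a sulfonyl sulfur. Among the compounds with values here, no single-change pair among the measured compounds tells the size of such a swap, so the expectation rests on compound 2, whose value 1400 nM with an open-chain dialkylamino group on the sulfonyl sulfur suggests a step downward. The step from compound 1 to compound 3 is expected to be a 3.9-fold lower number from compound 1 to compound 3 (0.59 log units; beyond the scatter). For compound 3 the expected value is 6000 nM, within a range of 1500 nM to 20000 nM.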

Compound 3, half-maximal inhibitory concentration: 300 nM
Estimate against measurement, compound 3: 20-fold (1.30 log units) above; the whole stated range lies above it.
By their numbers in this assay, from the lowest: compound 3; then compound 2; then compound 1.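

In this assay, within the data shown here, the swap of morpholin-4-yl for ethyl(propyl)amino on a sulfonyl sulfur gives a 78-fold lower number from compound 1 to compound 3 (1.89 log units; beyond the scatter) and is the first single-change step at this position. It shows that the group here strongly shifts the number, with the open-chain group on the lower side. No evidence is available to explain why this swap has such a large effect.

The compounds shown do not separate the loss of the ring from the loss of its oxygen, which piperidin-1-yl at the same place could do. Going by these compounds, how dimethylamino or dipropylamino would compare also stays open.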